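Adding a methyl to an inactive benzyl ether

The compounds below may be only part of what the source reports. "The series", "measured", "known", "first", "only" and "open" are said of these compounds alone.

Measured in a functional assay on THP-1 cells (Homo sapiens) for inhibition, read by sulforhodamine B assay, with a stated time of 48 h; a higher number here means a weaker inhibitor, a lower number a stronger inhibitor:
- Compound 1 `COc1ccc(C(O)(Cc2ccc(C)cc2)c2cccc3ccccc23)c(OC)c1OC` gives > 20000 nM, a limit.
- Compound 2 `COc1ccc(C(OCc2ccccc2)c2cccc3ccccc23)c(OC)c1OC` gives > 20000 nM, a limit.
- Compound 3 `C=C(c1ccc(OC)c(OC)c1OC)c1cccc2ccccc12` gives 12500 nM, a number.

Compound 2 gives no number in this assay: its > 20000 nM is a limit of the assay. It is not alone there, since the set shows (the limit of > 20000 nM in this assay, at which 2 of the 3 values shown sit). Only compound 3 returns an actual value.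

Compound 4 `COc1ccc(C(OCc2ccc(C)cc2)c2cccc3ccccc23)c(OC)c1OC` differs from compound 2 by one change, benzyloxy to (4-methylbenzyl)oxy, with methyl in place of hydrogen on an aromatic carbon. For the measured compounds named here, no measured pair isolates this change. The closest hint is compound 1, which also carries a 4-methylbenzyl group and gives > 20000 nM, again a limit. A shift beyond the usual scatter is therefore not expected, and compound 4 will most likely stay at the limit. The expected size of the change, a step that the limit leaves unreadable from compound 2 to compound 4, is small. For compound 4 the estimated value is 22000 nM, with an expected range from 11000 nM to 45000 nM.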

Compound 4, half-maximal inhibitory concentration: > 20000 nM
Compound 4 gave a limit, no number; the forecaster's own chance of this, stated with the estimate: 75%; the middle value is on the limit's open side.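

In this assay compound 4 returned > 20000 nM, a limit and not a number. Compound 2 sits at the same limit, so no step can be read between compound 2 and compound 4. The compounds shown leave open whether methyl in place of hydrogen on an aromatic carbon changes inhibition at all.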